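The compounds below may be only part of what the source reports. "The series", "measured", "known", "first", "only" and "open" are said of these compounds alone.

In a functional assay on WM 266-4 cells (Homo sapiens) for antiproliferative activity, read by MTT assay, with a stated time of 24 h (a lower number here means a stronger inhibitor of growth, a higher number a weaker inhibitor of growth), compound 1 `COc1ccc(C2CC(c3ccc4c(c3)OCCO4)=NN2c2ccccc2)cc1OC` gives 2160 nM, compound 2 `Fc1ccccc1C1CC(c2ccc3c(c2)OCCO3)=NN1c1ccccc1` gives 9120 nM and compound 3 `c1ccc(N2N=C(c3ccc4c(c3)OCCO4)CC2c2ccc3ccccc3c2)cc1` gives 13900 nM. Compound 3 sits level with compound 2, as a 1.5-fold higher number from compound 2 to compound 3 (0.18 log units; within the scatter) shows, and both lie above compound 1. Compound 4 `COc1ccc(C2CC(c3ccc4c(c3)OCCO4)=NN2c2ccccc2)cc1` carries 4-methoxyphenyl in place of naphthalen-2-yl on a saturated ring carbon. Within the data shown here, the nearest precedent is a 6.4-fold higher number from compound 1 to compound 3 (0.81 log units; beyond the scatter), read in reverse, as compound 1 also bears methoxy on that phenyl. a 4.2-fold higher number from compound 1 to compound 2 (0.63 log units; beyond the scatter) shows a similar loss with 2-fluorophenyl. A modest move to a lower number is therefore expected, slightly smaller than the reverse of the first step, with an estimated 4.0-fold lower number from compound 3 to compound 4 (0.60 log units; beyond the scatter). Compound 4 is expected at 3500 nM, with an estimated range of 1500 nM to 9000 nM.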

Compound 4, concentration for 50% growth inhibition: > 100000 nM
Compound 4: no number, only a limit; the forecaster's own chance of this, stated with the estimate: 2%; middle value at least 28-fold (1.45 log units) away from the limit.
By their numbers in this assay, from the lowest: compound 1; then compounds 2 and 3 (each within the scatter of the next). At a limit, above all of these: compound 4.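

In this assay compound 4 gives only a limit, not a number: the limit of > 100000 nM in this assay, at which 1 of the 4 values shown sits. Loss of a single methoxy from the 3,4-dimethoxyphenyl of compound 1 gives the largest listed step, an at least 46-fold higher number from compound 1 to compound 4 (1.66 log units; beyond the scatter), so the outcome at this saturated ring carbon turns on one aromatic substituent. Resemblance to compound 1 does not track the numbers here: 4-methoxyphenyl stands beyond both less similar groups, with an at least 7.1-fold higher number from compound 3 to compound 4 (0.85 log units; beyond the scatter) and an at least 10-fold higher number from compound 2 to compound 4 (1.04 log units; beyond the scatter).

As far as these compounds go, how far compound 4 lies past its limit stays open. Also open, from the compounds shown here alone, is whether 3-methoxyphenyl, or a hydroxy or dimethylamino group on that phenyl, would return a number near that of compound 1.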